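Methyl in place of methoxy on the benzyl ring

The compounds below may be only part of what the source reports. "The series", "measured", "known", "first", "only" and "open" are said of these compounds alone.

Compound 1 `O=C(NC1CCN(Cc2ccccc2Cl)CC1)c1cccc2ccccc12` gives 329 nM in an assay on isolated protein for displacement of a labelled ligand from D(4) dopamine receptor (Homo sapiens); on this read-out higher numbers stand for weaker inhibition and lower numbers for stronger inhibition. Compound 2 `O=C(NC1CCN(Cc2ccc(Br)cc2)CC1)c1cccc2ccccc12` gives 44 nM. Compound 3 `COc1cccc(CN2CCC(NC(=O)c3cccc4ccccc34)CC2)c1` gives 168 nM.

Compound 3 holds the second highest of the three numbers: the step of a 2.0-fold lower number from compound 1 to compound 3 (0.29 log units; within the scatter) stays within the scatter, while a 3.8-fold higher number from compound 2 to compound 3 (0.58 log units; beyond the scatter) lies beyond it. Compound 4 `Cc1cccc(CN2CCC(NC(=O)c3cccc4ccccc34)CC2)c1` differs from compound 3 by methyl in place of methoxy on an aromatic carbon. Going by the values given here, no measured step alters only one group on that ring; the steps of a 7.5-fold lower number from compound 1 to compound 2 (0.87 log units; beyond the scatter) and a 2.0-fold lower number from compound 1 to compound 3 (0.29 log units; within the scatter) each exchange the whole substituted ring, so they bear on the change only loosely. Among the compounds with values here, with so small a change and no direct precedent, the expected step is a 1.1-fold lower number from compound 3 to compound 4 (0.05 log units; within the scatter), not beyond the scatter. Compound 4 is therefore estimated at 150 nM, ranging from 60 nM to 400 nM.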

Compound 4, inhibition constant: 77 nM
For compound 4 the middle estimate is 1.9-fold (0.29 log units) above the measured one, within the range that was stated.
By their numbers in this assay, from the lowest: compounds 2 and 4 (each within the scatter of the next); then compounds 3 and 1 (each within the scatter of the next).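

At this position on the ring, meta to a large group, a single small swap is enough to move the number: methyl in place of methoxy gives a modest step just past the scatter (a 2.2-fold lower number from compound 3 to compound 4 (0.34 log units; beyond the scatter)). Across whole-ring exchanges, the 3-methylphenyl compound cannot be told apart from the 4-bromophenyl one (a 1.8-fold higher number from compound 2 to compound 4 (0.24 log units; within the scatter)), yet it stays clearly apart from the 2-chlorophenyl one (a 4.3-fold lower number from compound 1 to compound 4 (0.63 log units; beyond the scatter)). No measurement shown here accounts for this difference.

From the compounds shown here alone, how the same position responds to a hydroxyl, an amine or plain hydrogen remains open. So does whether methyl itself helps or the loss of methoxy alone is enough.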